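The source may hold more compounds than are shown below. What is called first, only, known or untested is meant among the compounds shown, and "the series" means these compounds.

In an ADME assay on microsomes from liver (Homo sapiens) for metabolic stability, with a stated time of 10 min, tested at 0.5 uM (on this read-out lower numbers stand for a less stable compound and higher numbers for a more stable compound), compound 1 (`Cc1noc(C)c1[C@@H]1C[C@@](C)(c2ccc(F)cc2F)N=C(N)S1`) gives 24%, and compound 2 (`Cc1onc(-c2ccc(F)cc2)c1[C@@H]1C[C@@](C)(c2ccc(F)cc2F)N=C(N)S1`) sits level with it at 24%. Compound 3 (`Cc1noc(-c2ccccc2)c1[C@@H]1C[C@@](C)(c2ccc(F)cc2F)N=C(N)S1`) has not been measured yet. It differs from compound 1 at one place, with phenyl in place of methyl on an aromatic carbon, next to the ring oxygen: phenyl in place of methyl on an aromatic carbon. Within the data shown here, only one measured step bears on this change. In compound 2, 4-fluorophenyl takes the place of the other methyl, so the comparison is close but not exact, and that step shows no change at the digits printed from compound 1 to compound 2 (within the scatter). On this single precedent, no shift beyond the scatter is expected in this assay, and the estimated step is a number 1 percentage points lower from compound 1 to compound 3 (within the scatter). For compound 3 the expected value is 23%, with an estimated range of 11% to 37%.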

Compound 3, percent of the compound remaining: 39%
Compound 3: middle estimate off by 16 percentage points, on the low side, outside the stated range (above it).
By their numbers in this assay, from the lowest: compounds 1 and 2 (each within the scatter of the next); then compound 3.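

In this assay, replacing the methyl next to the ring oxygen with phenyl is not neutral: it gives a number 15 percentage points higher from compound 1 to compound 3 (beyond the scatter). Among these compounds, the only earlier step, at the other methyl, showed no change at the digits printed from compound 1 to compound 2 (within the scatter), so that flat result does not hold for every swap of a methyl for a larger aromatic ring on this core. No measurement at hand says why the phenyl step raises the percentage remaining.

The two steps differ in both position and group, phenyl in one and 4-fluorophenyl in the other, so they cannot show which of the two matters. As far as these compounds go, it also remains open whether the rise needs an aromatic ring at all, or whether a longer chain such as propyl, or an amine, at this position would behave in the same way.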